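The source may hold more compounds than are shown below. What is called first, only, known or untested is meant among the compounds shown, and "the series" means these compounds.

Compound 2 `O=C1COc2ccc(-c3nn(-c4ccc(Cl)cc4)cc3-c3ccccc3)cc2N1` is the starting point of this step. In a functional assay on MV4-11 cells (Homo sapiens) for cytotoxicity, read by colorimetric assay and MTT assay, with a stated time of 3 days, tested at 1 uM (a higher number here means a weaker effect of the compound at the concentration tested, a lower number a stronger effect), compound 2 gives 108%. Among the measured compounds shown here, its only measured neighbour is compound 1 `COc1ccc(-n2cc(-c3ccccc3)c(-c3ccc4c(c3)NC(=O)CO4)n2)cc1`, which in this assay gives 106%; the two numbers sit together within the scatter and do not separate, so compound 2 cannot be placed above or below compound 1.

The step to compound 3 `O=C1COc2ccc(-c3nn(-c4ccc(F)cc4)cc3-c3ccccc3)cc2N1` is fluoro in place of chloro on an aromatic carbon. For the measured compounds named here, the one measured step that bears on it is the exchange at the same aromatic carbon, a number 2 percentage points higher from compound 1 to compound 2 (within the scatter), a change that stayed within the scatter. Two halogens of different size at this position, or a methoxy group, therefore give no sign of moving the read-out in this assay; a shift beyond the scatter in either direction is not expected from the data available.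

For compound 3 the expected value in this assay is 106%, with a range from 95% to 117%. The estimated step of a number 2 percentage points lower from compound 2 to compound 3 (within the scatter) lies within the scatter.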

Compound 3, a percentage reported as activity, at one concentration (the size of the read-out at that concentration, not a potency): 107%
Estimate against measurement, compound 3: 1 percentage points below; the range from low to high includes it.
By their numbers in this assay, from the lowest: compounds 1, 3 and 2 (each within the scatter of the next).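

In this assay the halogen exchange alone gives a number 1 percentage points lower from compound 2 to compound 3 (within the scatter) and the exchange of methoxy for fluoro gives a number 1 percentage points higher from compound 1 to compound 3 (within the scatter) so the fluoro compound joins the other two without separating from either. This position, on an aromatic carbon para to a large group, has now carried chloro, fluoro and methoxy, and none of the three groups separates from the others in this read-out. The result adds a second halogen and closes the set of three pairs, yet no evidence is available to explain the flat read-out.

Still open, going by these compounds, is whether an amine, a carboxylic acid or a longer chain at this carbon would move the read-out beyond the scatter. The compounds shown also leave open whether a change elsewhere on the shared core, such as at the amide hydrogen, would do so.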